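A few compounds are considered here, and "the series" means these few. Any claim that something is new, unique, unknown or untested is made for them only; others in the source may bear on it.

Measured compounds:
compound 1 `Cc1ccc(NC(=O)NC(=O)c2ccc(OCc3ccccc3)cc2)cc1-c1nc2ccccc2[nH]1`: 39400 nM
compound 2 `Cc1ccc(NC(=O)NC(=O)c2ccc(OCc3cccc(F)c3)cc2)cc1-c1nc2ccccc2[nH]1`: 44800 nM

Both numbers come from a functional assay on MGC-803 cells (Homo sapiens) for inhibition, read by MTT assay, with a stated time of 48 h; a higher number here means a weaker inhibitor, a lower number a stronger inhibitor. In this assay compound 1 gives 39400 nM and compound 2 gives 44800 nM; the two lie within the scatter of each other, as the step of a 1.1-fold higher number from compound 1 to compound 2 (0.06 log units; within the scatter) shows, so compound 2 is not set apart from compound 1 on the numbers at hand.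

Compound 3 `Cc1ccc(NC(=O)NC(=O)c2ccc(OCc3ccc(Cl)c(Cl)c3)cc2)cc1-c1nc2ccccc2[nH]1` has not yet been measured. Relative to compound 2 the change is 3,4-dichlorophenyl in place of 3-fluorophenyl on a saturated chain carbon bound to an oxygen on an aromatic ring. Going by the values given here, the only measured step that touches this part of the molecule, a 1.1-fold higher number from compound 1 to compound 2 (0.06 log units; within the scatter), concerns a fluoro substituent alone and stayed within the scatter. Among the compounds with values here, no measured pair shows a chlorine, a second halogen, or a change of this size in this assay, so the step from compound 2 to compound 3 cannot be read off directly. The expectation is therefore a step in this assay no larger than the scatter, with a wide range around it, a 1.3-fold lower number from compound 2 to compound 3 (0.11 log units; within the scatter). For compound 3 in this assay the estimate is 35000 nM, within 12000 nM to 100000 nM.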

Compound 3, half-maximal inhibitory concentration: 6080 nM
The estimate for compound 3 lay 5.8-fold (0.76 log units) above the measured number; measured number outside the range, below it.
By their numbers in this assay, from the lowest: compound 3; then compounds 1 and 2 (each within the scatter of the next).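

In this assay, the place on a saturated chain carbon bound to an oxygen on an aromatic ring proves responsive to the aryl group it carries: 3,4-dichlorophenyl in place of 3-fluorophenyl gives a 7.4-fold lower number from compound 2 to compound 3 (0.87 log units; beyond the scatter) and 3,4-dichlorophenyl in place of phenyl gives a 6.5-fold lower number from compound 1 to compound 3 (0.81 log units; beyond the scatter), whereas the fluoro change alone gave a 1.1-fold higher number from compound 1 to compound 2 (0.06 log units; within the scatter) and did not separate the first two compounds. Compound 3 is therefore the strongest inhibitor of the three, with the 3-fluorobenzyl and unsubstituted benzyl ethers forming a single level and the 3,4-dichlorobenzyl ether alone standing apart from it. No measurement on hand bears on why this change has the effect seen.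

The step to compound 3 changes the kind, number and placing of halogen together, so the share of each remains unresolved, and a single chlorine on the phenyl ring would be needed to begin separating them. Also open, going by these compounds, is whether the gain is specific to halogen or would extend to a methyl, methoxy or trifluoromethyl group on the same ring.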